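Swapping the side chain of compound 3 for a longer one

This account rests on a few compounds, and the source may have more. Where it says the series, first, only, none or still open, it means among the compounds named here.

Of the compounds shown here, three have been tested in a functional assay on the whole organism (Tail, strain ICR) with Mus musculus as the target, in the tail flick test, with a stated time of 30 min, at a dose of 25 umol/kg by the oral route; a lower number here means a weaker effect, a higher number a stronger effect of the compound at the dose given. Compound 1 `O=C(CN(c1nc(Cl)nc2[nH]cnc12)C1CC1)N[C@@H](CO)C(=O)O` gives 38.7%. Compound 2 `CC[C@H](C)[C@H](NC(=O)CN(c1ncnc2c1ncn2C1CCCCO1)C1CC1)C(=O)OCc1ccccc1` gives 25.6%. Compound 3 `O=C(CN(c1ncnc2c1ncn2C1CCCCO1)C1CC1)N[C@@H](CO)C(=O)OCc1ccccc1` gives 27.8%. Among these three numbers compound 3 stands second highest: its nearest neighbour is compound 2, whose number is close enough to fall within the scatter, while compound 1 lies further away, beyond the scatter.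

Compound 4 `CC(C)(C)OC(=O)NCCCC[C@H](NC(=O)CN(c1ncnc2c1ncn2C1CCCCO1)C1CC1)C(=O)OCc1ccccc1` has not yet been measured in this assay. It differs from compound 3 at one place: 3-((tert-butoxycarbonyl)amino)propyl in place of hydroxy on a saturated chain carbon, two bonds along the chain from an amide-type nitrogen and a carbonyl carbon.

Going by the values given here, one measured step bears on this change, since it alters the same side chain on the same carbon. That step was a number 2.2 percentage points higher from compound 2 to compound 3 (within the scatter), which replaced one side chain with another of a different size and did not move the number beyond the scatter. A larger side chain entering compound 4 is therefore expected to make little difference as well, with no step beyond the scatter in either direction being the likeliest outcome.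

The step from compound 3 to compound 4 is accordingly estimated as a number 0.8 percentage points lower from compound 3 to compound 4 (within the scatter). Compound 4 is expected to give about 27% in this assay, with a likely range from 14% to 40%.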

Compound 4, a percentage reported as activity, at one dose (the size of the read-out at that dose, not a potency): 18.3%
Compound 4: middle estimate off by 8.7 percentage points, on the high side; low and high end bracket the measured number.
By their numbers in this assay, from the lowest: compounds 4, 2 and 3 (each within the scatter of the next); then compound 1.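

Moving along the side chain on this saturated chain carbon in this assay, hydroxymethyl gives way to 4-((tert-butoxycarbonyl)amino)butyl, and the results are a number 9.5 percentage points lower from compound 3 to compound 4 (within the scatter) and a number 7.3 percentage points lower from compound 2 to compound 4 (within the scatter) for the two changes that lead to this new side chain. The group entering at this place counts 11 heavy atoms against the 1 that leaves, so this is a much larger change in size than the earlier swap of sec-butyl for hydroxymethyl, yet these steps still do not go beyond the scatter, and the three side chains cannot be ranked against one another. No measured evidence is available here to explain these numbers.

Going by these compounds, what stays open is whether the butyl chain and the tert-butoxycarbonyl group at its end count separately, which a free amine or a carboxylic acid at the end of the same chain would help to show. A still longer chain, or a side chain carrying a ring, would show whether this place continues to accept larger groups without a step beyond the scatter.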